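Shortening the Chain on a Sulfur across Two Cores

The source may hold more compounds than are shown below. What is called first, only, known or untested is meant among the compounds shown, and "the series" means these compounds.

Compound 1 `Cc1cc(-n2cccc2)cn2c(CSCCc3ccccc3)cnc12` and compound 2 `Cc1cc(-n2cccc2)cn2c(CSCc3ccccc3)cnc12` share one core, while compound 3 `Cc1cc(N2CCCC2)c2ncc(CSCCc3ccccc3)n2c1` and compound 4 `Cc1cc(N2CCCC2)c2ncc(CSCc3ccccc3)n2c1` share another; the difference between the two cores is not broken down here. In an ADME assay on HEL cells (Homo sapiens) for cytotoxicity, with a stated time of 3 days (a lower number here means that less compound is tolerated, a higher number that more compound is tolerated), compound 1 gives >= 4 ug/mL, which is a limit of the assay. In this assay compound 2 gives 20 ug/mL. The change between them is phenyl in place of benzyl on a saturated chain carbon bound to a sulfur, and the step that the limit leaves unreadable from compound 1 to compound 2 cannot be read because compound 1 sits at the limit of >= 4 ug/mL in this assay, at which 1 of the 3 values shown sits. In this assay compound 3 gives > 100 ug/mL, again a limit. The same change, (phenyl in place of benzyl on a saturated chain carbon bound to a sulfur), leads to compound 4. The measured step is unreadable, and compound 3 rests at the limit of > 100 ug/mL in this assay, at which 1 of the 3 values shown sits, so the expectation is loose. Compound 4 is expected to give 60 ug/mL in this assay. The step of an at least 1.6-fold lower number from compound 3 to compound 4 (0.22 log units; that floor lies within the scatter) that this estimate means carries that uncertainty.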

Compound 4, minimum cytotoxic concentration: >= 20 ug/mL
Compound 4: only a limit was reported (the forecaster's own chance of this, stated with the estimate: 50%); the middle value does not contradict the limit.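

The step between compound 3 and compound 4 cannot be read: each of their two values in this assay is a limit. The compounds shown leave open how far the change from phenethyl to benzyl shifts tolerated concentration on either core.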